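The compounds below may be only part of what the source reports. "The series", "measured", "known", "first", "only" and "open" are said of these compounds alone.

Compound 1 `N#Cc1ccc(NC(=O)c2ccc3cccnc3c2O)cc1` gives 370 nM in a functional assay on HL-60 cells (Homo sapiens) for cytotoxicity, read by luminescence and CellTiter-Glo, with a stated time of 3 days; a lower number here means a stronger inhibitor, a higher number a weaker inhibitor.
Compound 2 `Cc1cc(C#N)ccc1NC(=O)c1ccc2cccnc2c1O` gives 710 nM in this assay.

Compound 2 has the highest of the two numbers; its nearest neighbour is compound 1, from which it is separated by a 1.9-fold higher number from compound 1 to compound 2 (0.28 log units; within the scatter). Compound 3 `N#Cc1ccc(NC(=O)c2ccc3cccnc3c2O)c(C#N)c1` differs from compound 2 by cyano in place of methyl on an aromatic carbon. For the measured compounds named here, the only measured step, methyl in place of hydrogen, touched the same position but stayed within the scatter, so no step beyond the scatter in this assay is expected here either. Compound 3 is therefore estimated at 500 nM, between 200 nM and 1500 nM, which would mean an expected step of a 1.4-fold lower number from compound 2 to compound 3 (0.15 log units; within the scatter).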

Compound 3, half-maximal inhibitory concentration: 890 nM
Estimate against measurement, compound 3: 1.8-fold (0.25 log units) below; the range from low to high includes it.
By their numbers in this assay, from the lowest: compounds 1, 2 and 3 (each within the scatter of the next, the first and the last beyond it).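

In this assay, cyano in place of methyl at this position gives a 1.3-fold higher number from compound 2 to compound 3 (0.10 log units; within the scatter) and so does not separate the two groups. Cyano in place of hydrogen at the same position gives a 2.4-fold higher number from compound 1 to compound 3 (0.38 log units; beyond the scatter) and is the first step here to pass beyond the scatter, though only modestly. No evidence is available to explain this result.

The compounds shown leave open whether an amine, a methoxy group or a chlorine atom at this position would stay within the scatter of compound 1. They also leave open how a longer chain would fare there.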